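Chain length at the ring nitrogen, follicle-stimulating hormone receptor agonism

The source may hold more compounds than are shown below. What is called first, only, known or untested is meant among the compounds shown, and "the series" means these compounds.

Measured compounds:
compound 1 `CCCCCCCCCN1CC(=O)N(C)[C@@H](Cc2ccc(-c3cc(OC)c(OC)c(OC)c3)cc2)C1=O`, 900 nM
compound 2 `CCCCCCCCN1CC(=O)N(C)[C@@H](Cc2ccc(-c3cc(OC)c(OC)c(OC)c3)cc2)C1=O`, 400 nM
compound 3 `CCCCCCN1CC(=O)N(C)[C@@H](Cc2ccc(-c3cc(OC)c(OC)c(OC)c3)cc2)C1=O`, 3000 nM

In a functional assay for agonist activity at follicle-stimulating hormone receptor (Homo sapiens), read by a luciferase reporter (on this read-out higher numbers stand for an effect only at larger amounts of compound and lower numbers for an effect already at smaller amounts), compound 3 stands at the highest of the three numbers: a 3.3-fold higher number from compound 1 to compound 3 (0.52 log units; beyond the scatter) and a 7.5-fold higher number from compound 2 to compound 3 (0.88 log units; beyond the scatter), so shortening the chain on the ring nitrogen has so far only pushed the number up, while the opposite direction gave a 2.3-fold lower number from compound 1 to compound 2 (0.35 log units; beyond the scatter). No pattern beyond these three compounds is claimed.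

Compound 4 `CCCCCN1CC(=O)N(C)[C@@H](Cc2ccc(-c3cc(OC)c(OC)c(OC)c3)cc2)C1=O` continues the same cut: hydrogen in place of methyl on a saturated chain carbon, five bonds along the chain from an amide-type nitrogen in a ring. The two steps that bear on it are the shortenings already seen, a 3.3-fold higher number from compound 1 to compound 3 (0.52 log units; beyond the scatter) and a 7.5-fold higher number from compound 2 to compound 3 (0.88 log units; beyond the scatter), both modest and both beyond the scatter, both raising the number. For the step from compound 3 to compound 4 a further rise in this assay is therefore expected, of roughly the size of the earlier shortenings, though a shorter cut than either of them.

Compound 4 is expected to give 7000 nM in this assay, within 2500 nM to 20000 nM, which corresponds to an estimated step of a 2.3-fold higher number from compound 3 to compound 4 (0.37 log units; beyond the scatter).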

Compound 4, half-maximal effective concentration: 9000 nM
The estimate for compound 4 lay 1.3-fold (0.11 log units) below the measured number; the range from low to high includes it.
By their numbers in this assay, from the lowest: compound 2; then compound 1; then compound 3; then compound 4.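

In this assay, going by these compounds alone, the shortening continues to raise the number at this position, with a 3.0-fold higher number from compound 3 to compound 4 (0.48 log units; beyond the scatter), and the widest span in the set, a 23-fold higher number from compound 2 to compound 4 (1.35 log units; beyond the scatter), is the only step here printed as large, while the span from the longest chain is smaller, a 10-fold higher number from compound 1 to compound 4 (1.00 log units; beyond the scatter), and compound 1 goes against any reading that a shorter chain always gives a higher number. Hydrogen in place of methyl therefore carries neither one direction nor one size along the chain: the same change on two cores in this assay, a 2.3-fold lower number (0.35 log units; beyond the scatter) from compound 1 to compound 2 and a 3.0-fold higher number (0.48 log units; beyond the scatter) from compound 3 to compound 4, 6.8-fold (0.83 log units) apart, beyond the scatter of two such steps. The larger cut likewise depends on the chain it starts from, so the outcome of a shortening cannot be read from the number of carbons removed alone: the same change on two cores in this assay, a 3.3-fold higher number (0.52 log units; beyond the scatter) from compound 1 to compound 3 and a 23-fold higher number (1.35 log units; beyond the scatter) from compound 2 to compound 4, 6.8-fold (0.83 log units) apart, beyond the scatter of two such steps.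

The compounds shown leave open whether a heptyl chain would give a lower number than compound 2, and so whether the lowest number of the series lies at the chain of compound 2. They also leave open whether the rise continues on a butyl or propyl chain, and how a branched chain, or an amine or carboxylic acid at the chain end, would read in this assay.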